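This account rests on a few compounds, and the source may have more. Where it says the series, first, only, none or still open, it means among the compounds named here.

Of the compounds shown here, three sharing one core have been measured in a functional assay on MDA-MB-231 cells (Homo sapiens) for inhibition, read by MTT assay, with a stated time of 48 h; a lower number here means a stronger inhibitor, a higher number a weaker inhibitor. Compound 1, `COc1ccc(N(C)c2nc(C)nc3ccccc23)cc1OCCN`, gives 682 nM. Compound 2, `COc1ccc(N(C)c2nc(C)nc3ccccc23)cc1C(=O)NCC[Se]C#N`, gives 1250 nM. Compound 3, `COc1ccc(N(C)c2nc(C)nc3ccccc23)cc1C(=O)OCCC[Se]C#N`, gives 1180 nM, which places it second highest of the three numbers; its nearest neighbour is compound 2, and its furthest is compound 1, with both gaps within the scatter.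

Compound 4, `COc1ccc(N(C)c2nc(C)nc3ccccc23)cc1C(=O)OCCCCC[Se]C#N`, has not yet been measured. It differs from compound 3 in one place: a group of 5 heavy atoms (3 carbon, 1 nitrogen, 1 selenium; no ring) in place of a group of 3 heavy atoms (1 carbon, 1 nitrogen, 1 selenium; no ring), on a saturated chain carbon, three bonds along the chain from an oxygen next to a carbonyl group. The chain that carries the selenocyanate is therefore longer, while the rest of the molecule is unchanged.

For the measured compounds named here, two measured steps bear on this. The change a 1.8-fold higher number from compound 1 to compound 2 (0.26 log units; within the scatter) and the change a 1.7-fold higher number from compound 1 to compound 3 (0.24 log units; within the scatter) show that adding a selenocyanate-bearing chain to the core moves the number only within the scatter, and the change a 1.1-fold lower number from compound 2 to compound 3 (0.03 log units; within the scatter) shows that altering the link and the chain length between those two compounds also stays within the scatter. Nothing measured here suggests that a longer chain should shift the number beyond the scatter in either direction.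

The expectation for compound 4 is therefore a step of a 1.1-fold higher number from compound 3 to compound 4 (0.04 log units; within the scatter), that is, no change beyond the scatter. Compound 4 is estimated at 1300 nM, with a range from 650 nM to 2600 nM.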

Compound 4, half-maximal inhibitory concentration: 851 nM
Compound 4: middle estimate off by 1.5-fold (0.18 log units), on the high side; the measured number falls inside the stated range.
By their numbers in this assay, from the lowest: compounds 1, 4, 3 and 2 (each within the scatter of the next).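

In this assay, the group of 5 heavy atoms in place of the group of 3 heavy atoms, on a saturated chain carbon, three bonds along the chain from an oxygen next to a carbonyl group, gives a 1.4-fold lower number from compound 3 to compound 4 (0.14 log units; within the scatter). This is the only step among these compounds that changes the length of the selenocyanate-bearing chain and nothing else, and it shows that this added length leaves the number within the scatter. The wider change on the carbonyl carbon, which alters the link as well as the chain, gives a 1.5-fold lower number from compound 2 to compound 4 (0.17 log units; within the scatter), which is also within the scatter, and no independent measurement is available to interpret either step.

With a single chain-length step, the compounds shown leave open whether a still longer chain, or a shorter chain on the same ester link, would move the number beyond the scatter. They also leave open what a thiocyanate at the chain end in place of the selenocyanate would do, and whether the longer chain would behave the same way on the amide link of compound 2.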